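Adding an Ethyl Group to a Compound with a Low Number in the NF-kappa-B Assay

The source may hold more compounds than are shown below. What is called first, only, known or untested is meant among the compounds shown, and "the series" means these compounds.

Compound 1 `O=C1CCC(N2C(=O)c3ccc(Nc4ccccc4)cc3C2=O)C(=O)N1` gives 6% in an assay on FRT-Jurkat cells for inhibition of nuclear factor NF-kappa-B complex (Homo sapiens), read by flow cytometry, with a stated time of 24 h, tested at 10 uM (a lower number here means less inhibition, a higher number more inhibition at the concentration tested (going by the name of the read-out)), the lowest of three numbers, though its gaps to compound 3 `C=C(OCC)c1ccc(Nc2cccc3c2C(=O)N(C2CCC(=O)NC2=O)C3=O)cc1` at 10% and compound 2 `COc1ccc(Nc2cccc3c2C(=O)N(C2CCC(=O)NC2=O)C3=O)cc1` at 13% both lie within the scatter. Compound 4 `CCc1ccc(Nc2ccc3c(c2)C(=O)N(C2CCC(=O)NC2=O)C3=O)cc1` differs from compound 1 by ethyl in place of hydrogen on an aromatic carbon, on an aromatic carbon of a six-membered aromatic ring of carbon only, para to a large group. Going by the values given here, the one comparable step, a swap of a group on the same kind of ring, is a number 3 percentage points lower from compound 2 to compound 3 (within the scatter), within the scatter. A step of no more than the scatter is therefore expected here, a number 2 percentage points higher from compound 1 to compound 4 (within the scatter). Compound 4 is estimated to give 8%, with a range from 0% to 20%.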

Compound 4, a percentage reported as inhibition, at one concentration (the size of the read-out at that concentration, not a potency): 5%
Compound 4: the middle estimate sits 3 percentage points above what was measured; measured number inside the range.
By their numbers in this assay, from the lowest: compounds 4, 1, 3 and 2 (each within the scatter of the next).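

In this assay, ethyl in place of hydrogen gives a number 1 percentage points lower from compound 1 to compound 4 (within the scatter), so adding this group to a ring position para to a large group leaves the read-out unchanged within the scatter. Until now, the only step shown was a swap of one group for another; this one shows a group added where only hydrogen stood. No supporting measurement is available to explain this result.

From the compounds shown here alone, whether an amine or a carboxylic acid at this position would give a different number remains open. So does the effect of a longer chain.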